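Replacing the carbamoyl arm of compound 3

A few compounds are considered here, and "the series" means these few. Any claim that something is new, unique, unknown or untested is made for them only; others in the source may bear on it.

Values measured so far in a functional assay on KB cells (Homo sapiens) for antiproliferative activity, read by sulforhodamine B assay, with a stated time of 3 days; on this read-out higher numbers stand for weaker inhibition of growth and lower numbers for stronger inhibition of growth:
Compound 1 `COc1ccc(NC(=O)c2cccc(Nc3ncc(F)c(Nc4ccc(F)cc4)n3)c2)cc1` gives > 10000 nM as a limit of the assay, not a number
Compound 2 `COCC(=O)Nc1cccc(Nc2ncc(F)c(Nc3ccc(F)cc3)n2)c1` gives 6250 nM
Compound 3 `Cn1ccnc1NC(=O)c1cccc(Nc2ncc(F)c(Nc3ccc(F)cc3)n2)c1` gives 14600 nM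

Of the two true numbers, the higher belongs to compound 3, at 14600 nM, which means weaker inhibition of growth. Compound 2 is its nearest neighbour. The next compound is compound 4 `CN(C)CC(=O)Nc1cccc(Nc2ncc(F)c(Nc3ccc(F)cc3)n2)c1`, and the change is this: (((dimethylamino)methyl)carbonyl)amino in place of (1-methyl-1H-imidazol-2-yl)carbamoyl on an aromatic carbon. The entering group resembles the ((methoxymethyl)carbonyl)amino of compound 2, so the most useful measurement is a 2.3-fold higher number from compound 2 to compound 3 (0.37 log units; beyond the scatter). That step brought in the same group that compound 4 now gives up. The other steps help little: an at least 1.6-fold lower number from compound 1 to compound 2 (0.20 log units; that floor lies within the scatter), and there is a step that the limit leaves unreadable from compound 1 to compound 3. A modest drop back towards the level of compound 2 is therefore expected in this assay. The estimated change is a 2.9-fold lower number from compound 3 to compound 4 (0.47 log units; beyond the scatter). For compound 4 the estimated value is 5000 nM, with an expected range of 1800 nM to 14000 nM.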

Compound 4, concentration for 50% growth inhibition: 1260 nM
Compound 4: the middle estimate sits 4.0-fold (0.60 log units) above what was measured; measured number outside the range, below it.
By their numbers in this assay, from the lowest: compound 4; then compound 2; then compound 3.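

In this assay, a 5.0-fold lower number from compound 2 to compound 4 (0.70 log units; beyond the scatter) comes from dimethylamino in place of methoxy on the saturated chain carbon bound to the carbonyl carbon, so the outcome at this position depends on that one group and not only on the arm as a whole. Exchanging the entire arm gives a 12-fold lower number from compound 3 to compound 4 (1.06 log units; beyond the scatter) and makes compound 4 the most potent of the compounds shown. The change also gives an at least 7.9-fold lower number from compound 1 to compound 4 (0.89 log units; beyond the scatter) as a floor only, as the value of compound 1 is a limit: the limit of > 10000 nM in this assay, at which 1 of the 4 values shown sits.

As far as these compounds go, what the dimethylamino group contributes remains open, since these compounds cannot separate its nitrogen from its size. A pyrrolidine, a morpholine, a primary amine or a longer chain before the amine could each test this.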